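Dropping the hydroxymethyl group from compound 3

The source may hold more compounds than are shown below. What is called first, only, known or untested is meant among the compounds shown, and "the series" means these compounds.

In a functional assay on PC-6 cells (Homo sapiens) for cytotoxicity, read by MTT assay, with a stated time of 3 days (on this read-out lower numbers stand for stronger inhibition and higher numbers for weaker inhibition), compound 1 `CC(C)(C)c1cc2c(N/N=C/c3ccc4c(c3)CNCC4)ncnc2s1` gives 0.069 ug/mL on this read-out and compound 2 `CC(C)N1Cc2ccc(/C=N/Nc3ncnc4sc(C(C)(C)C)cc34)cc2C1` gives 0.134 ug/mL on the same read-out. Compound 3 `CC(C)(C)c1cc2c(N/N=C/c3ccc(CO)cc3)ncnc2s1` gives 0.556 ug/mL here, the highest number of the three and beyond the scatter from both of the others, which makes it the weakest of the measured set.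

The change from compound 3 to compound 4 `CC(C)(C)c1cc2c(N/N=C/c3ccccc3)ncnc2s1` is hydrogen in place of hydroxymethyl on an aromatic carbon in the structure: hydrogen in place of hydroxymethyl on an aromatic carbon, para to a large group. Among the measured compounds shown here, no measured pair isolates this change, so the data give no direct precedent for its size. The expectation therefore starts from compound 3 at 0.556 ug/mL as the nearest reference. The step expected in this assay is a 1.2-fold higher number from compound 3 to compound 4 (0.07 log units; within the scatter) and is estimated to stay within the scatter, with no firm direction. For compound 4 the estimated value is 0.65 ug/mL with an expected range from 0.2 ug/mL to 2 ug/mL on this read-out.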

Compound 4, half-maximal inhibitory concentration: 6.54 ug/mL
Compound 4: the middle estimate sits 10-fold (1.00 log units) below what was measured; the measured number lies above the stated range.
By their numbers in this assay, from the lowest: compounds 1 and 2 (each within the scatter of the next); then compound 3; then compound 4.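

In this assay, putting hydrogen in place of hydroxymethyl on this aromatic carbon, para to a large group, gives a 12-fold higher number from compound 3 to compound 4 (1.07 log units; beyond the scatter), which on this read-out means much weaker inhibition. Among the compounds shown here, this is the first pair to isolate a single change, and it shows that this position is sensitive: 4-(hydroxymethyl)phenyl gives far stronger inhibition here than phenyl. Nothing measured in this set bears on what lies behind the step.

The compounds shown leave open whether the oxygen or the added carbon of hydroxymethyl accounts for the difference; a methyl group, a methoxymethyl group or an aminomethyl group at the same carbon would separate the two. As far as these compounds go, whether a carboxylic acid or a longer chain ending in hydroxyl would hold or extend the effect also remains open.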